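Biaryl terminus swap in a cyclopropanecarboxamide series

The compounds below may be only part of what the source reports. "The series", "measured", "known", "first", "only" and "open" are said of these compounds alone.

For the measured compounds named here, compound 3 `CC(C)C[C@H](N)CN(C(=O)[C@@H]1C[C@H]1c1ccccc1)c1ccc(-c2cccs2)cc1` gives 1500 nM in a functional assay for agonist activity at G protein-coupled receptor 88 (Homo sapiens), read by HTRF and cAMP accumulation (on this read-out lower numbers stand for an effect already at smaller amounts and higher numbers for an effect only at larger amounts of compound), the highest of the three numbers measured so far; compound 1 `CC[C@H](C)[C@H](N)CN(C(=O)[C@@H]1C[C@H]1c1ccc(F)cc1)c1ccc(-c2ccccc2)cc1` gives 600 nM and compound 2 `CC[C@H](C)[C@H](N)CN(C(=O)[C@@H]1C[C@H]1c1cccc(F)c1)c1ccc(-c2ccccc2)cc1` gives 560 nM, both beyond the scatter below compound 3, though each differs from compound 3 in more than one place. Going by the values given here, the only single-point step, a 1.1-fold lower number from compound 1 to compound 2 (0.03 log units; within the scatter), concerns the fluorine on the ring at the saturated ring carbon and says nothing about the biaryl end. Compound 4 `CC(C)C[C@H](N)CN(C(=O)[C@@H]1C[C@H]1c1ccccc1)c1ccc(-c2ccc(F)cc2)cc1` carries 4-fluorophenyl in place of thiophen-2-yl on an aromatic carbon. Among the compounds with values here, no measured step bears on this change directly; the lower numbers of compounds 1 and 2, which hold a phenyl at that end, only suggest that a six-membered carbon ring there is tolerated. A modest step toward lower numbers, a 1.9-fold lower number from compound 3 to compound 4 (0.27 log units; within the scatter), is therefore expected. Compound 4 is estimated at 800 nM, within 300 nM to 2500 nM.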

Compound 4, half-maximal effective concentration: 900 nM
Compound 4: the middle estimate sits 1.1-fold (0.05 log units) below what was measured; the range from low to high includes it.
By their numbers in this assay, from the lowest: compounds 2, 1, 4 and 3 (each within the scatter of the next, the first and the last beyond it).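

For the compounds shown here, replacing thiophen-2-yl with 4-fluorophenyl (a 1.7-fold lower number from compound 3 to compound 4 (0.22 log units; within the scatter)) gives the first direct reading at this position, para to a large group. The step lies within the scatter, so this assay does not separate these two terminal rings on this core. No available evidence explains this reading.

Going by these compounds, the separate contribution of the fluorine stays open, as an unsubstituted phenyl on this same core would be needed to read it. Also open, on these data alone, is how a terminal ring carrying an amine or a carboxylic acid would read.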